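Side-chain change in a series near the assay limit

This account rests on a few compounds, and the source may have more. Where it says the series, first, only, none or still open, it means among the compounds named here.

In a functional assay on HCT-116 cells (Homo sapiens) for inhibition, read by MTT assay, with a stated time of 48 h (on this read-out higher numbers stand for weaker inhibition and lower numbers for stronger inhibition), compound 3 `COc1cc(-c2nnc(SCc3ccc(C)cc3)n2-c2ccc(N(C)C)cc2)cc(OC)c1OC` gives > 60000 nM, which is a limit and not a number. Compound 1 `COc1ccc(-n2c(SCC(=O)c3ccc(F)cc3)nnc2-c2cc(OC)c(OC)c(OC)c2)cc1`, which also carries the (4-fluorophenyl)carbonyl group, gives > 60000 nM, again a limit. Going by the values given here, compound 2 `COc1cc(-c2nnc(SCc3ccccc3)n2-c2ccc(N(C)C)cc2)cc(OC)c1OC` gives 54000 nM, the only actual number so far. The series therefore sits largely at the limit of > 60000 nM in this assay, at which 2 of the 3 values shown sit.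

Compound 4 `COc1cc(-c2nnc(SCC(=O)c3ccc(F)cc3)n2-c2ccc(N(C)C)cc2)cc(OC)c1OC` departs from compound 3 in the side chain: (4-fluorophenyl)carbonyl in place of 4-methylphenyl on a saturated chain carbon bound to a sulfur. In other words, 4-methylbenzyl gives way to ((4-fluorophenyl)carbonyl)methyl on the sulfur.

Among the compounds with values here, no measured step covers this change directly. The only one, an at least 1.1-fold higher number from compound 2 to compound 3 (0.04 log units; that floor lies within the scatter), is a different change, methyl in place of hydrogen on an aromatic carbon, and it stays within the scatter. On that basis no step beyond the scatter is expected in this assay, and a further reading at the limit is quite possible.

The expected step is an at least 1.0-fold lower number from compound 3 to compound 4 (0.03 log units; that floor lies within the scatter).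

For compound 4 the estimate is 55000 nM, with an expected range of 18000 nM to 100000 nM.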

Compound 4, half-maximal inhibitory concentration: 31100 nM
The estimate for compound 4 lay 1.8-fold (0.25 log units) above the measured number; measured number inside the range.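

In this assay compound 4 gives a second actual number in the series, so (4-fluorophenyl)carbonyl on the saturated chain carbon bound to a sulfur reads inside the range where the 4-methylphenyl of compound 3 reads only as a limit. Set against phenyl, the same group gives a 1.7-fold lower number from compound 2 to compound 4 (0.24 log units; within the scatter), so this change shows no step beyond the scatter. For 4-methylphenyl, and for dimethylamino in place of methoxy on an aromatic carbon, only floors can be read, an at least 1.9-fold lower number from compound 3 to compound 4 (0.28 log units; that floor lies within the scatter) and an at least 1.9-fold lower number from compound 1 to compound 4 (0.28 log units; that floor lies within the scatter), because the starting values are limits: the limit of > 60000 nM in this assay, at which 2 of the 4 values shown sit.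

The compounds shown do not separate the carbonyl from the fluorine in the entering group. As far as these compounds go, how a carboxylic acid or a longer chain on the sulfur would read in this assay remains open.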